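Adding an Ethoxy Group to a Two-Armed Pyrimidine Amine

The compounds below may be only part of what the source reports. "The series", "measured", "known", "first", "only" and "open" are said of these compounds alone.

Measured compounds:
- Compound 1, `C#CCOc1ccc(-c2cc(-c3ccc(OCC#C)c(OCC)c3)nc(-c3ccccc3)n2)cc1`, 29000 nM
- Compound 2, `C#CCOc1ccc(-c2cc(-c3ccc(OCC#C)cc3)nc(N)n2)cc1`, 3300 nM

Both compounds were tested in an assay on BTI-TN-5B1-4 cells for inhibition of Amine oxidase [flavin-containing] B (Homo sapiens), read by fluorescence and Amplex Red, using microsomes, with a stated time of 30 min; on this read-out higher numbers stand for weaker inhibition and lower numbers for stronger inhibition. Of the two numbers at hand, compound 2 gives the lower one, 3300 nM, while compound 1 gives 29000 nM; the gap between them lies beyond the usual scatter. Going by the values given here, the two structures differ in more than one place, so their two values show only that compound 2 is the stronger of the pair, not which part of the difference matters.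

Compound 3, `C#CCOc1ccc(-c2cc(-c3ccc(OCC#C)c(OCC)c3)nc(N)n2)cc1`, has not yet been measured in this assay. It differs from compound 2 in one place: ethoxy in place of hydrogen on an aromatic carbon. Among the compounds with values here, no pair of measured compounds isolates this single change, so there is no direct guide to its size or direction. Within the data shown here, the only other compound carrying the same ethoxy group is compound 1, whose weaker number cannot be attributed to that group alone.

On this basis, the step from compound 2 to compound 3 in this assay is estimated as a 1.5-fold higher number from compound 2 to compound 3 (0.18 log units; within the scatter), a change expected to stay within or near the scatter. Compound 3 is therefore expected to give about 5000 nM, with a plausible range from 1500 nM to 16000 nM.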

Compound 3, half-maximal inhibitory concentration: 14000 nM
Beside the measured number, compound 3's estimate is 2.8-fold (0.45 log units) below it; measured number inside the range.
By their numbers in this assay, from the lowest: compound 2; then compound 3; then compound 1.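

In this assay, ethoxy in place of hydrogen on an aromatic carbon, ortho to a propargyloxy group, gives a 4.2-fold higher number from compound 2 to compound 3 (0.63 log units; beyond the scatter) and so goes with weaker inhibition, a direct reading of this single change that the two earlier compounds could not provide. Compound 3 also isolates a second place on the shared core: amino in place of phenyl on an aromatic carbon gives a 2.1-fold lower number from compound 1 to compound 3 (0.32 log units; beyond the scatter) with the ethoxy group present in both compounds. Nothing measured here explains either step.

As far as these compounds go, it remains open whether this position tolerates only hydrogen or whether a methoxy group, a fluorine atom or a hydroxyl group would keep the inhibition seen with hydrogen. From the compounds shown here alone, it is also open whether adding the ethoxy group would have a similar effect on a core carrying phenyl in place of amino, as the step seen here comes from the core carrying amino.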